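This account rests on a few compounds, and the source may have more. Where it says the series, first, only, none or still open, it means among the compounds named here.

Compound 3 `Cc1ccc2ncc(S(=O)(=O)c3cc(Cl)cc(Cl)c3)c(N3CCC(C)CC3)c2c1` stands second highest of the three numbers measured in an assay on isolated protein for displacement of a labelled ligand from metabotropic glutamate receptor 5 (Homo sapiens), with a stated time of 60 min, tested at 1 uM (on this read-out lower numbers stand for less inhibition and higher numbers for more inhibition at the one concentration tested (going by the name of the read-out)), where compound 3 gives 75%. Its nearest neighbour is compound 1 `CC1CCN(c2c(S(=O)(=O)c3cc(Cl)cc(Cl)c3)cnc3ccc(F)cc23)CC1`, which in this assay gives 69%; that step is a number 6 percentage points higher from compound 1 to compound 3 (within the scatter), methyl in place of fluoro on an aromatic carbon. Furthest stands compound 2 `Cc1ccc2ncc(S(=O)(=O)c3ccc(F)cc3)c(N3CCC(C)CC3)c2c1`, which in this assay gives 90%; that step is a number 15 percentage points lower from compound 2 to compound 3 (beyond the scatter), 3,5-dichlorophenyl in place of 4-fluorophenyl on a sulfonyl sulfur. Compound 4 `Cc1cc(C)cc(S(=O)(=O)c2cnc3ccc(C)cc3c2N2CCC(C)CC2)c1` differs from compound 3 at that same sulfonyl sulfur: 3,5-dimethylphenyl in place of 3,5-dichlorophenyl on a sulfonyl sulfur. Among the compounds with values here, only the step from compound 2 to compound 3 touches the group on the sulfonyl sulfur, and it was modest, beyond the scatter; no measured step exchanges chlorine for methyl on that group, so no direction can be read from the measured compounds. The expected step for compound 4 is a number 1 percentage points lower from compound 3 to compound 4 (within the scatter), not beyond the scatter in either direction. In this assay compound 4 is estimated at 74%, between 55% and 90%.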

Compound 4, a percentage reported as inhibition, at one concentration (the size of the read-out at that concentration, not a potency): 80%
Compound 4: middle estimate off by 6 percentage points, on the low side, within the range that was stated.
By their numbers in this assay, from the lowest: compounds 1, 3, 4 and 2 (each within the scatter of the next, the first and the last beyond it).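

In this assay, putting 3,5-dimethylphenyl in place of 3,5-dichlorophenyl on the sulfonyl sulfur gives a number 5 percentage points higher from compound 3 to compound 4 (within the scatter), so on this read-out the two groups cannot be told apart. Coming from the 4-fluorophenyl group, the change gives a number 10 percentage points lower from compound 2 to compound 4 (within the scatter), whereas the 3,5-dichlorophenyl group had stood beyond the scatter from it, so the 3,5-dimethylphenyl group is separated from neither of the other two groups at this place. Nothing available explains these numbers.

The compounds shown leave open whether an unsubstituted phenyl, a 3,5-dimethoxyphenyl or a saturated cyclohexyl on the sulfonyl sulfur would stay in this same range. Since each reading comes from one concentration, they also leave open whether the potencies of these compounds differ.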